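Taking One Methoxy Away from Compound 3

The compounds below may be only part of what the source reports. "The series", "measured", "known", "first", "only" and "open" are said of these compounds alone.

Values measured in a functional assay on SMMC-7721 cells (Homo sapiens) for cytotoxicity, read by MTT assay, with a stated time of 72 h (on this read-out lower numbers stand for stronger inhibition and higher numbers for weaker inhibition), are these
Compound 1 `CC(C)=C1C(=O)N(c2ccc(Cl)cc2)N(c2ccc(Cl)cc2)C1=O` gives 45600 nM
Compound 2 `CCC(C)=C1C(=O)N(c2ccc(Cl)cc2)N(c2ccc(Cl)cc2)C1=O` gives 49200 nM
Compound 3 `COc1cc(C=C2C(=O)N(c3ccc(Cl)cc3)N(c3ccc(Cl)cc3)C2=O)cc(OC)c1OC` gives 29500 nM

In this assay compound 3 at 29500 nM sits within the usual scatter of both compound 1 and compound 2, so these three cannot be ranked. Compound 4 `COc1ccc(C=C2C(=O)N(c3ccc(Cl)cc3)N(c3ccc(Cl)cc3)C2=O)cc1OC` is compound 3 with a single change (hydrogen in place of methoxy on an aromatic carbon), namely hydrogen in place of methoxy on an aromatic carbon.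

Within the data shown here, only one measured step links two compounds by a single change: a 1.1-fold higher number from compound 1 to compound 2 (0.03 log units; within the scatter) for methyl in place of hydrogen on a saturated chain carbon. That change lies on a chain and not on an aromatic carbon, so it is only a loose guide. Among the measured compounds shown here, no measured pair tests a methoxy group on this ring directly. Still, compound 1 at 45600 nM has no such aromatic ring and remains within the scatter of compound 3, so removing one methoxy is not expected to shift the number beyond the scatter, in either direction. The expected step is a 1.1-fold higher number from compound 3 to compound 4 (0.04 log units; within the scatter) and this estimate stays within the scatter. For compound 4 the estimated value is 32000 nM with an expected range from 16000 nM to 60000 nM in this read-out.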

Compound 4, half-maximal inhibitory concentration: > 128000 nM
Compound 4: no number, only a limit; the forecaster's own chance of this, stated with the estimate: 10%; middle value at least 4.0-fold (0.60 log units) away from the limit.
By their numbers in this assay, from the lowest: compounds 3, 1 and 2 (each within the scatter of the next). At a limit, above all of these: compound 4.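

In this assay, hydrogen in place of methoxy on an aromatic carbon gives an at least 4.3-fold higher number from compound 3 to compound 4 (0.63 log units; beyond the scatter), the first step shown that lies beyond the scatter. Among these compounds, the only earlier step, a 1.1-fold higher number from compound 1 to compound 2 (0.03 log units; within the scatter), sits on a chain and stays within the scatter, so it gave no sign that a single small change could matter this much. This position on the ring, ortho to a methoxy group and meta to a large group, is therefore the first place shown where a change clearly moves the read-out, and removing the methoxy there goes toward weaker inhibition. Compound 4 has a limit and not a number: the limit of > 128000 nM in this assay, at which 1 of the 4 values shown sits.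

The compounds shown leave open whether methoxy itself matters or whether any group on this carbon would serve, as only methoxy and hydrogen appear there. A hydroxyl, a chlorine or an amine on the same aromatic carbon would help separate these two readings, and an ethoxy group would show whether a longer chain at this position is tolerated.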